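Trifluoromethoxy in place of cyano: expectations for compound 3

A few compounds are considered here, and "the series" means these few. Any claim that something is new, unique, unknown or untested is made for them only; others in the source may bear on it.

Compound 1 `COc1ccc(O)c(C(=O)Nc2ccc(C#N)cc2)c1`: > 10000 nM (a limit of the assay)
Compound 2 `N#Cc1ccc(NC(=O)c2cc(F)ccc2O)cc1`: 1420 nM

Among the compounds with values here, in a functional assay on HL-60 cells (Homo sapiens) for cytotoxicity, read by luminescence and CellTiter-Glo, with a stated time of 3 days (on this read-out higher numbers stand for weaker inhibition and lower numbers for stronger inhibition), compound 2 holds the only true number. Compound 1 stands at the limit of > 10000 nM in this assay, at which 1 of the 2 values shown sits, and gives no number. Within the data shown here, the one measured step is fluoro in place of methoxy on an aromatic carbon, and it is an at least 7.0-fold lower number from compound 1 to compound 2 (0.84 log units; beyond the scatter) (beyond the scatter).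

Compound 3 `O=C(Nc1ccc(OC(F)(F)F)cc1)c1cc(F)ccc1O` changes a different place, with trifluoromethoxy in place of cyano on an aromatic carbon, para to a large group (trifluoromethoxy in place of cyano on an aromatic carbon). Among the measured compounds shown here, the step of an at least 7.0-fold lower number from compound 1 to compound 2 (0.84 log units; beyond the scatter) shows that this assay can respond to one substitution, but no step has been measured at this place. No change beyond the scatter is therefore expected, though the uncertainty is wide. The expected step is a 1.4-fold lower number from compound 2 to compound 3 (0.15 log units; within the scatter) (an estimate). For compound 3 the estimated value is 1000 nM (expected range 250 nM to 4500 nM).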

Compound 3, half-maximal inhibitory concentration: 850 nM
Beside the measured number, compound 3's estimate is 1.2-fold (0.07 log units) above it, within the range that was stated.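

In this assay, within the data shown here, the place that carries cyano in compound 2 now has its first measured step, a 1.7-fold lower number from compound 2 to compound 3 (0.22 log units; within the scatter), whereas the only earlier step, an at least 7.0-fold lower number from compound 1 to compound 2 (0.84 log units; beyond the scatter), was a fluoro-for-methoxy exchange at a different place. At this place, trifluoromethoxy with 5 heavy atoms stands in for cyano with 2 heavy atoms, and the two numbers lie within the scatter of each other, so this assay does not separate the two groups. Nothing measured here bears on why these two groups give such numbers.

On these data alone, whether an amine, a carboxylic acid or a longer alkyl chain at this place would give a similar number remains open. Also open, as far as these compounds go, is how the same exchange would read on the core of compound 1, which gives > 10000 nM, a limit of the assay.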